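Inverting One Stereocentre at the Assay Limit

The source may hold more compounds than are shown below. What is called first, only, known or untested is meant among the compounds shown, and "the series" means these compounds.

Compound 1 `CCc1oc([C@H](C)/C=C(\C)[C@H](OC(C)=O)[C@H](C)[C@@H](OC(=O)CC(C)C)[C@@H](C)c2oc([C@@H](C)[C@H](CC)OC(C)=O)c(C)c(=O)c2C)c(C)c(=O)c1C` reads 28000 nM in a functional assay on A549 cells (Homo sapiens) for inhibition, read by MTT assay, with a stated time of 72 h (a higher number here means a weaker inhibitor, a lower number a stronger inhibitor), as a measured number. Compound 2 `CCC(=O)[C@@H](C)c1oc([C@H](C)[C@@H]2O[C@](O)([C@@H](C)c3oc(CC)c(C)c(=O)c3C)[C@@H](C)[C@@H](O)[C@@H]2C)c(C)c(=O)c1C` reads > 100000 nM in this assay and that entry is a limit of the assay, not a number. Compound 3 `CCC(=O)[C@H](C)c1oc([C@H](C)[C@@H]2O[C@](O)([C@@H](C)c3oc(CC)c(C)c(=O)c3C)[C@@H](C)[C@@H](O)[C@@H]2C)c(C)c(=O)c1C` differs from compound 2 as follows (the two compounds have the same atoms and bonds and differ only in configuration as drawn: 1 of 8 stereo elements differ; a stereocentre at a saturated chain carbon is drawn S in compound 2 and R in compound 3) with a stereocentre at a saturated chain carbon drawn S in compound 2 and R in compound 3. Among the compounds with values here, no measured pair here shows what such an inversion does, so no step beyond the scatter is expected in this assay and no direction is favoured. The expectation rests on compound 2 and its entry of > 100000 nM as the only anchor, and that entry is a limit. The expected change is a number no higher from compound 2 to compound 3 (the limit leaves the size open) on this reading. For compound 3 the estimated half-maximal inhibitory concentration is 100000 nM with an expected range from 40000 nM to 200000 nM and a report of a limit alone is likely.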

Compound 3, half-maximal inhibitory concentration: > 100000 nM
Compound 3 gave a limit, no number; the forecaster's own chance of this, stated with the estimate: 70%; the middle value sits exactly at the limit.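

No step can be read between compound 2 and compound 3 in this assay, because both entries are limits of the assay, not numbers: the limit of > 100000 nM in this assay, at which 2 of the 3 values shown sit.

The compounds shown leave open whether inverting the stereocentre at the saturated chain carbon changes the half-maximal inhibitory concentration at all, and in which direction.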